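Swapping bromo for piperidin-1-yl in an acylguanidine series

A few compounds are considered here, and "the series" means these few. Any claim that something is new, unique, unknown or untested is made for them only; others in the source may bear on it.

Measured so far:
compound 1, `CS(=O)(=O)c1cc(C(=O)N=C(N)N)c(N2CCCCC2)cc1N1CCCCC1`, in a functional assay for inhibition of sodium/hydrogen exchanger (Oryctolagus cuniculus) (on this read-out lower numbers stand for stronger inhibition and higher numbers for weaker inhibition), compound 1 gives 1000 nM
compound 2, `CS(=O)(=O)c1cc(C(=O)N=C(N)N)ccc1Br`, in this assay compound 2 gives 180 nM

Of these two numbers, compound 2 holds the lower one, and its nearest neighbour, compound 1, sits higher by a margin beyond the usual scatter. Compound 3, `CS(=O)(=O)c1cc(C(=O)N=C(N)N)ccc1N1CCCCC1`, is not yet measured. It differs from compound 2 in a single place: piperidin-1-yl in place of bromo on an aromatic carbon. Among the measured compounds shown here, no measured pair differs by exactly this change, so there is no direct guide. Still, compound 1, which carries piperidin-1-yl at two places, gives the higher number of 1000 nM, so compound 3 is expected to move upward in this assay by a modest step of a 2.2-fold higher number from compound 2 to compound 3 (0.35 log units; beyond the scatter), a step that may yet fall within the scatter. For compound 3 the estimate is 400 nM, with a range from 100 nM to 1600 nM.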

Compound 3, half-maximal inhibitory concentration: 130 nM
For compound 3 the middle estimate is 3.1-fold (0.49 log units) above the measured one; the measured number falls inside the stated range.
By their numbers in this assay, from the lowest: compounds 3 and 2 (each within the scatter of the next); then compound 1.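

In this assay, piperidin-1-yl in place of bromo on this aromatic carbon, ortho to a methylsulfonyl group, gives a 1.4-fold lower number from compound 2 to compound 3 (0.14 log units; within the scatter), so a group of 6 heavy atoms with a ring and a single bromine cannot be told apart here. Among the compounds shown here, putting hydrogen in place of the other piperidin-1-yl gives a 7.7-fold lower number from compound 1 to compound 3 (0.89 log units; beyond the scatter), and this step lies beyond the scatter, so the weaker inhibition of compound 1 goes with that second piperidin-1-yl and not with the one it shares with compound 3. No measurement at hand explains either step. The compounds shown leave open how other groups behave at this position, such as a dimethylamino group or a carboxylic acid. They also leave open how much the methylsulfonyl group contributes, as it stays the same in all three compounds.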